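The source may report more compounds than this note shows. Statements on the series, on what has been measured and on what is new or still open speak of the compounds shown alone.

In a functional assay on HT cells (Homo sapiens) for cytotoxicity, read by CCK-8 assay, with a stated time of 72 h (a lower number here means a stronger inhibitor, a higher number a weaker inhibitor), compound 1 `Cn1cc(NC(=O)c2cnc3ccc(N[C@@H]4CCCNC4)nn23)c(C(F)F)n1` gives 40100 nM. As far as these compounds go, compound 2 `Cn1cc(NC(=O)c2cnc3ccc(N[C@H]4CCCNC4)nn23)c(C(F)F)n1` reads > 50000 nM, which is a limit of the assay and not a number, so its true position is unknown. Going by the values given here, the only measured step, an at least 1.2-fold higher number from compound 1 to compound 2 (0.09 log units; that floor lies within the scatter), stays within the scatter and rests on (the fact that compounds 1 and 2 differ only in the configuration as drawn). Compound 3 `Cn1cc(NC(=O)c2cnc3ccc(N[C@@H]4CCNC4)nn23)c(C(F)F)n1` departs from compound 2 in the amine ring: pyrrolidin-3-yl in place of piperidin-3-yl on a nitrogen on an aromatic ring. Among the compounds with values here, no measured step changes ring size, so the evidence is indirect. Within the data shown here, the only guide is the small step between compound 1 and compound 2, and no shift beyond the scatter is expected in this assay, in either direction. The expected step is an at least 1.1-fold lower number from compound 2 to compound 3 (0.04 log units; that floor lies within the scatter). For compound 3 the estimate is 45000 nM, with an expected range of 18000 nM to 100000 nM.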

Compound 3, half-maximal inhibitory concentration: > 50000 nM
Compound 3 gave a limit, no number; the forecaster's own chance of this, stated with the estimate: 55%; middle value at least 1.1-fold (0.04 log units) from the limit.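

In this assay the change now reaches ring size as well as drawn configuration, and compound 3 reads > 50000 nM, a limit of the assay and not a number. Going by these compounds alone, the one readable step is an at least 1.2-fold higher number from compound 1 to compound 3 (0.09 log units; that floor lies within the scatter), so pyrrolidin-3-yl in place of piperidin-3-yl shows no gain in this read-out. The step between compound 2 and compound 3 cannot be read, and the series gives little resolution here: the limit of > 50000 nM in this assay, at which 2 of the 3 values shown sit.

The compounds shown leave open whether an azetidin-3-yl group or an open-chain 2-aminoethyl group on a nitrogen on an aromatic ring would give a value clear of the limit. They also leave open how the opposite drawn configuration of the pyrrolidin-3-yl group reads in this assay.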